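The compounds below may be only part of what the source reports. "The series", "measured", "known", "first", "only" and "open" are said of these compounds alone.

Compound 1 `CC[C@H](C)[C@H](N)CN(C(=O)[C@@H]1C[C@H]1c1ccccc1)c1ccc(-c2ccccc2)cc1`: 230 nM; 800 nM (2 entries)
Compound 2 `CCc1ccc(-c2ccc(N(C[C@@H](N)[C@@H](C)CC)C(=O)[C@@H]3C[C@H]3c3ccccc3)cc2)cc1`: 44 nM
Compound 3 `CCCc1ccc(-c2ccc(N(C[C@@H](N)[C@@H](C)CC)C(=O)[C@@H]3C[C@H]3c3ccccc3)cc2)cc1`: 61 nM

All three were tested in a functional assay for agonist activity at G protein-coupled receptor 88 (Homo sapiens), read by HTRF and cAMP accumulation; a higher number here means that more compound is needed for the effect, a lower number that less compound is needed. Compound 1 carries the repeat entries (the several entries of compound 1 in this assay, 230 nM; 800 nM (2 entries)), which show how far repeats of one compound can drift. Compound 3 gives 61 nM, the larger of the two single numbers; its nearest neighbour is compound 2, and the step of a 1.4-fold higher number from compound 2 to compound 3 (0.14 log units; within the scatter) lies within the scatter. Compound 4 `CC[C@H](C)[C@H](N)CN(C(=O)[C@@H]1C[C@H]1c1ccccc1)c1ccc(-c2ccc(C(C)(C)C)cc2)cc1` has not been measured. It differs from compound 3 by tert-butyl in place of propyl on an aromatic carbon. Within the data shown here, the only measured step at this place is a 1.4-fold higher number from compound 2 to compound 3 (0.14 log units; within the scatter), which changed little, so the further change to tert-butyl is expected to shift the number in this assay by no more than the scatter. Compound 4 is therefore expected to give 70 nM (range 30 nM to 200 nM). That estimate means a step of a 1.1-fold higher number from compound 3 to compound 4 (0.06 log units; within the scatter).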

Compound 4, half-maximal effective concentration: 750 nM
Estimate against measurement, compound 4: 11-fold (1.03 log units) below; measured number outside the range, above it.
By their numbers in this assay, from the lowest: compounds 2 and 3 (each within the scatter of the next); then compound 4.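

Ethyl and propyl on this aromatic carbon cannot be told apart in this assay, which made the position look tolerant, but tert-butyl breaks that picture, giving a 12-fold higher number from compound 3 to compound 4 (1.09 log units; beyond the scatter) and a 17-fold higher number from compound 2 to compound 4 (1.23 log units; beyond the scatter). A straight chain and tert-butyl are therefore not interchangeable here. Both steps are also larger than the drift between repeats: the several entries of compound 1 in this assay, 230 nM; 800 nM (2 entries).

The compounds shown leave open whether isopropyl, a smaller branched group, or butyl, a longer straight chain, would behave like propyl or like tert-butyl.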